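The source may report more compounds than this note shows. Statements on the series, on what has been measured and on what is new or still open speak of the compounds shown alone.

Among the measured compounds shown here, compound 3 `Clc1ccc(C2=NN(C3=NC(c4ccccc4)CS3)C(c3cccc4ccccc34)C2)cc1` carries the highest number of the three measured members in a functional assay on BGC-823 cells (Homo sapiens) for inhibition, read by CCK-8 assay, with a stated time of 48 h (on this read-out lower numbers stand for stronger inhibition and higher numbers for weaker inhibition), at 19600 nM. Compound 2 `Brc1ccc(C2=NN(C3=NC(c4ccccc4)CS3)C(c3cccc4ccccc34)C2)cc1` gives 17400 nM, and a 1.1-fold higher number from compound 2 to compound 3 (0.05 log units; within the scatter). Compound 1 `Cc1ccc(C2=NN(C3=NC(c4ccccc4)CS3)C(c3cccc4ccccc34)C2)cc1C` gives 8460 nM; a 2.1-fold higher number from compound 1 to compound 2 (0.31 log units; beyond the scatter), and a 2.3-fold higher number from compound 1 to compound 3 (0.36 log units; beyond the scatter). Compound 4 `COc1ccc(C2=NN(C3=NC(c4ccccc4)CS3)C(c3cccc4ccccc34)C2)cc1` is the next member: methoxy in place of chloro on an aromatic carbon. For the measured compounds named here, no measured step swaps a halogen for methoxy, so the three steps are only indirect guides: the two steps from the dimethyl compound to the halogen compounds were modest, and the halogen-for-halogen step fell within the scatter. Compound 4 is therefore expected to shift this assay by a 1.4-fold lower number from compound 3 to compound 4 (0.15 log units; within the scatter), a small step with a wide margin. The estimate for compound 4 is 14000 nM, between 5000 nM and 40000 nM.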

Compound 4, half-maximal inhibitory concentration: 9510 nM
Compound 4: the middle estimate sits 1.5-fold (0.17 log units) above what was measured, and the stated range covers the measured number.
By their numbers in this assay, from the lowest: compounds 1, 4, 2 and 3 (each within the scatter of the next, the first and the last beyond it).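

Within this assay, methoxy in place of chloro on this aromatic carbon gives a step beyond the scatter (a 2.1-fold lower number from compound 3 to compound 4 (0.31 log units; beyond the scatter)), while methoxy in place of bromo stays within it (a 1.8-fold lower number from compound 2 to compound 4 (0.26 log units; within the scatter)). The 4-methoxyphenyl and 3,4-dimethylphenyl compounds also fall within the scatter of each other (a 1.1-fold higher number from compound 1 to compound 4 (0.05 log units; within the scatter)), so only compound 3 is separated from compound 4 and compound 1. No measured data here account for these steps.

Open, as far as these compounds go, is how an amine, a carboxylic acid or a longer chain such as butoxy at this place would compare with methoxy.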